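The compounds below may be only part of what the source reports. "The series", "measured", "known", "first", "only" and "open" are said of these compounds alone.

Compound 1, with structure `CNC(=O)c1cc(C(=O)N[C@H]2[C@@H]3COC[C@@H]32)cc2c1OC[C@H]2c1cccc(OC)c1`, was tested in a physicochemical assay for solubility; a higher number here means a more soluble compound, a lower number a less soluble compound. In this assay compound 1 gives >= 186 ug/mL, and that figure is a limit of the assay rather than an exact number. A second compound, compound 2 with structure `CNC(=O)c1cc(C(=O)NC)c2c(c1)[C@](C)(c1ccccc1)CO2`, gives >= 132 ug/mL in this assay, which is also a limit. Both measured compounds therefore sit at a limit, one at the limit of >= 186 ug/mL in this assay, at which 1 of the 2 values shown sits, and one at the limit of >= 132 ug/mL in this assay, at which 1 of the 2 values shown sits, so the numbers give no direction for a change, and the two compounds differ in more than one place.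

The unmeasured compound 3 has structure `CNC(=O)c1cc(C(=O)N[C@H]2[C@@H]3COC[C@@H]32)cc2c1OC[C@H]2c1cccc2[nH]ccc12`. It differs from compound 1 by 1H-indol-4-yl in place of 3-methoxyphenyl on a saturated ring carbon. Among the compounds with values here, with no measured step to lean on, the step of an at least 1.2-fold lower number from compound 1 to compound 3 (0.09 log units; that floor lies within the scatter) is expected to be small or none beyond the scatter. Compound 3 is therefore estimated to give 150 ug/mL in this assay, within a range from 40 ug/mL to 250 ug/mL.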

Compound 3, solubility: >= 171 ug/mL
Compound 3: no number, only a limit; the forecaster's own chance of this, stated with the estimate: 55%; middle value at least 1.1-fold (0.05 log units) from the limit.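

In this assay compound 3 gives >= 171 ug/mL, which is a limit of the assay. Compound 1 also stands at a limit, so no step can be read from compound 1 to compound 3. As far as these compounds go, whether the 1H-indol-4-yl swap changes solubility at all remains open.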